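The source may hold more compounds than are shown below. What is called first, only, known or untested is meant among the compounds shown, and "the series" means these compounds.

Compound 1 `O=C(NC(c1nccs1)C1CCNCC1)c1ccc2cnccc2c1` gives 1570 nM in an assay on isolated protein for inhibition of RAC-alpha serine/threonine-protein kinase (Homo sapiens); a higher number here means a weaker inhibitor, a lower number a stronger inhibitor. Compound 2 `O=C(NC(c1ccc(F)c(F)c1)C1CCNCC1)c1ccc2cnccc2c1` gives 2680 nM; the step of a 1.7-fold higher number from compound 1 to compound 2 (0.23 log units; within the scatter) stays within the scatter, so the two numbers cannot be told apart. Compound 3 `O=C(NC(c1cnc(Cl)c(Cl)c1)C1CCNCC1)c1ccc2cnccc2c1` differs from compound 1 by 5,6-dichloropyridin-3-yl in place of 1,3-thiazol-2-yl on a saturated chain carbon bound to an amide-type nitrogen and a saturated ring carbon. For the measured compounds named here, the only measured step that bears on this, where another six-membered aromatic ring entered at the same place, was small. The expected step in this assay is therefore a 1.5-fold higher number from compound 1 to compound 3 (0.18 log units; within the scatter), nothing beyond the scatter. Compound 3 is estimated at 2400 nM, with a likely range from 900 nM to 6500 nM.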

Compound 3, half-maximal inhibitory concentration: 140 nM
Estimate against measurement, compound 3: 17-fold (1.23 log units) above, outside the stated range (below it).
By their numbers in this assay, from the lowest: compound 3; then compounds 1 and 2 (each within the scatter of the next).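

The place on the saturated chain carbon proves far more sensitive in this assay than the first two compounds suggested: 5,6-dichloropyridin-3-yl brings an 11-fold lower number from compound 1 to compound 3 (1.05 log units; beyond the scatter) and a 19-fold lower number from compound 2 to compound 3 (1.28 log units; beyond the scatter). A six-membered aromatic ring alone therefore does not settle the number, as 3,4-difluorophenyl stays within the scatter of 1,3-thiazol-2-yl. Nothing measured here gives a reason for the gain.

The ring nitrogen and the two chlorines change together, so their shares remain unseparated. A 3,4-dichlorophenyl ring, or a pyridine carrying one chlorine, would separate them.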